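The source may report more compounds than this note shows. Statements on the series, on what has been measured and on what is new or still open speak of the compounds shown alone.

Measured compounds:
Compound 1, `CCOC(=O)c1cc(=O)c2cc(CSC(=S)N(C(C)C)C(C)C)ccc2o1`, in a functional assay on SW480 cells (Homo sapiens) for antiproliferative activity, read by MTT assay, with a stated time of 72 h (on this read-out higher numbers stand for weaker inhibition and lower numbers for stronger inhibition), gives > 25000 nM, which is a limit of the assay rather than a number.
Compound 2, `O=c1cc(CSC(=S)N2CCCC2)oc2ccccc12`, in this assay gives 23400 nM.
Compound 3, `CN(C(=S)SCc1coc2ccccc2c1=O)c1ccccc1`, in this assay gives > 25000 nM, again a limit and not a number.

All three share the same core with a thiocarbonyl carbon carrying sulfur, and they differ only in the amine attached to that carbon. Compound 1 stands where only a limit is known: it sits at the limit of > 25000 nM in this assay, at which 2 of the 3 values shown sit, so its true potency is not pinned down beyond the fact that no clear inhibition was reached. Compound 2 gives a measured number close to that limit, and compound 3 also gives only a limit. None of the three shows strong inhibition of these cells.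

The unmeasured compound 4, `CCOC(=O)c1cc(=O)c2cc(CSC(=S)N3CCOCC3)ccc2o1`, is reached from compound 1 by one change: morpholin-4-yl in place of diisopropylamino on a thiocarbonyl carbon. Among the compounds with values here, no measured pair that differs in a single place is available, so nothing shows how such a change moves the numbers in this assay. Given that every value so far lies at or near the limit, compound 4 is expected to stay in the same weak region, with no step beyond the scatter in either direction. Compound 4 is estimated at 25000 nM, between 10000 nM and 60000 nM. The expected step is a number no higher from compound 1 to compound 4 (the limit leaves the size open), and a limit rather than a number is the most likely outcome.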

Compound 4, half-maximal inhibitory concentration: > 25000 nM
Compound 4 was reported as a limit; the forecaster's own chance of this, stated with the estimate: 70%; the middle value lies on the limit itself.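

Compound 1 and compound 4 are both reported only as limits in this assay, so no step from the change to morpholin-4-yl can be read between them: the limit of > 25000 nM in this assay, at which 3 of the 4 values shown sit.

The compounds shown leave open how the true potencies of compound 1 and compound 4 compare, and whether any amine on the thiocarbonyl carbon gives strong inhibition.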